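The compounds below may be only part of what the source reports. "The series", "measured", "known", "first", "only" and "open" are said of these compounds alone.

In a functional assay (strain AB) with Danio rerio as the target, read by microscopy, with a stated time of 1 h (on this read-out lower numbers stand for an effect already at smaller amounts and higher numbers for an effect only at larger amounts of compound), compound 1 `CCN1CCc2c(sc(NC(=O)Nc3ccccc3)c2C(N)=O)C1` gives > 25000 nM, which is a limit of the assay and not a number. Compound 2 `CCN1CCc2c(sc(NC(=O)Nc3ccc(Cl)cc3)c2C(N)=O)C1` gives 3120 nM, and compound 3 `CCN1CCc2c(sc(NC(=O)Nc3ccc(Br)cc3)c2C(N)=O)C1` gives 3130 nM. Going by the values given here, compound 3 therefore stands with compound 2 as one of the only two compounds with a measured number, and bromo in place of chloro changes nothing beyond the scatter: a 1.0-fold higher number from compound 2 to compound 3 (0.00 log units; within the scatter). Both halogens matter compared with hydrogen, with chloro giving an at least 8.0-fold lower number from compound 1 to compound 2 (0.90 log units; beyond the scatter) and bromo giving an at least 7.9-fold lower number from compound 1 to compound 3 (0.90 log units; beyond the scatter).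

Compound 4 `CCN1CCc2c(sc(NC(=O)NCc3cccc(Cl)c3)c2C(N)=O)C1` has 3-chlorobenzyl in place of 4-bromophenyl on an amide-type nitrogen. The measured steps bear on this only in part, since each swaps a single atom on an aromatic carbon and none changes the whole group. Compound 4 keeps a chloro, so a full fall back to the limit seen for compound 1 at > 25000 nM is not the likeliest outcome. A modest move towards a higher number in this assay is expected, with the estimated step being a 2.2-fold higher number from compound 3 to compound 4 (0.35 log units; beyond the scatter). The estimated value for compound 4 is 7000 nM, with an expected range from 2000 nM to 25000 nM.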

Compound 4, half-maximal effective concentration: > 25000 nM
Compound 4: no number, only a limit (the forecaster's own chance of this, stated with the estimate: 30%); middle value at least 3.5-fold (0.55 log units) from the limit.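

In this assay compound 4 gives only a limit of the assay and not a number: the limit of > 25000 nM in this assay, at which 2 of the 4 values shown sit. Keeping a chloro on the aromatic ring therefore does not preserve the effect, since 3-chlorobenzyl in place of 4-bromophenyl on the amide-type nitrogen gives an at least 7.9-fold higher number from compound 3 to compound 4 (0.90 log units; beyond the scatter), and 3-chlorobenzyl in place of 4-chlorophenyl gives an at least 8.0-fold higher number from compound 2 to compound 4 (0.90 log units; beyond the scatter). The earlier steps shown here showed only that a halogen on the phenyl ring matters, whereas these show that the effect also depends on the whole group on this nitrogen, and the step that links the two limits cannot be read.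

The compounds shown leave open whether the loss comes from the benzyl carbon or from the changed place of the chloro. They also leave open how an amine or a carboxylic acid on a longer chain at this nitrogen would read.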